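Methylation of a phenolic thiourea on an indole core

The compounds below may be only part of what the source reports. "The series", "measured", "known", "first", "only" and "open" are said of these compounds alone.

Two thioureas built on the same indole core were examined in an ADME assay on isolated protein for inhibition of peroxidase (Raphanus sativus), read by fluorescence and Amplex Red, tested at 5 uM; on this read-out higher numbers stand for a weaker effect at the one concentration tested and lower numbers for a stronger effect. Compound 1 `Oc1ccccc1NC(=S)Nc1ccc2[nH]ccc2c1` carries a hydroxy group on its second aromatic ring and gives 43.9% in this assay. Compound 2 `Oc1ccc(NC(=S)Nc2ccc3[nH]ccc3c2)cc1` carries the hydroxy group elsewhere on that ring, and compound 2 gives 41.5% in this assay. Compound 2 thus stands at a number that lies within the usual scatter of the number of compound 1, so the two measured compounds cannot be told apart on this read-out.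

Compound 3 `COc1ccc(NC(=S)Nc2ccc3[nH]ccc3c2)cc1` is the next compound and has not yet been measured. It differs from compound 2 in one place: methyl in place of hydrogen on an oxygen on an aromatic ring. For the measured compounds named here, no step between measured compounds describes the effect of such a change, so there is no measured basis for expecting a shift beyond the scatter in either direction.

Compound 3 is therefore estimated at 44% in this assay, with a range from 28% to 62%. This estimate means a step of a number 2.5 percentage points higher from compound 2 to compound 3 (within the scatter), which is expected to stay within the usual scatter.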

Compound 3, a percentage reported as activity, at one concentration (the size of the read-out at that concentration, not a potency): 67.6%
Estimate against measurement, compound 3: 23.6 percentage points below; measured number above the stated range.
By their numbers in this assay, from the lowest: compounds 2 and 1 (each within the scatter of the next); then compound 3.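

In this assay, the change from hydroxy to methoxy on this oxygen brings a number 26.1 percentage points higher from compound 2 to compound 3 (beyond the scatter), so the methoxy compound has the weaker effect at the one concentration tested. For the compounds shown here, the earlier pair showed only that placing the hydroxy group elsewhere on the second aromatic ring left compound 1 and compound 2 indistinguishable, whereas this single pair shows that replacing the hydrogen on that oxygen with methyl, a change of one heavy atom, can move the read-out beyond the scatter. Nothing available explains why this step occurs.

The compounds shown leave open whether the same exchange of hydroxy for methoxy would shift the read-out to a similar extent at the hydroxy position of compound 1, since this step rests on one pair alone. They also leave open whether the effect follows from losing the hydrogen or from adding carbon, a question that an ethoxy group, a longer chain on the oxygen, or an amine in place of the hydroxy group could help to separate.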